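Trifluoromethyl added to the methyl-bearing compound: expected exposure

The compounds below may be only part of what the source reports. "The series", "measured", "known", "first", "only" and "open" are said of these compounds alone.

Measured so far in an ADME assay on the whole organism (plasma) for pharmacokinetics, with Rattus norvegicus as the target, with a stated time of 24 h, at a dose of 10 mg/kg by the oral route; a lower number here means less compound in the circulation, a higher number more compound in the circulation at the dose given:
compound 1 `Cc1ccc2c(c1)c(-c1ccc[nH]c1=O)c(C(=O)NS(=O)(=O)C1CC1)n2Cc1cc(F)ccc1F` gives 4530 ng.h/mL
compound 2 `CCc1ccc2c(c1)c(-c1ccc[nH]c1=O)c(C(=O)NS(=O)(=O)C1CC1)n2Cc1cc(F)ccc1F` gives 6140 ng.h/mL

Compound 1 has a single measured neighbour on these numbers, and the two lie within the scatter of each other, with a 1.4-fold higher number from compound 1 to compound 2 (0.13 log units; within the scatter). That step places methyl in place of hydrogen on a saturated chain carbon bound to an aromatic carbon.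

Compound 3 `Cc1cc2c(-c3ccc[nH]c3=O)c(C(=O)NS(=O)(=O)C3CC3)n(Cc3cc(F)ccc3F)c2cc1C(F)(F)F` is still to be measured. It differs from compound 1 by trifluoromethyl in place of hydrogen on an aromatic carbon, ortho to a methyl group. Among the measured compounds shown here, no measured pair shows this change, so the one available step is only a loose guide. It is a different change at a different kind of carbon, and it did not move this assay beyond the scatter. No step beyond the scatter is therefore expected, and no direction can be argued from the data.

The expected change is a 1.1-fold higher number from compound 1 to compound 3 (0.04 log units; within the scatter). For compound 3 the estimated value is 5000 ng.h/mL, with an expected range of 1800 ng.h/mL to 14000 ng.h/mL.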

Compound 3, area under the concentration-time curve: 390 ng.h/mL
Beside the measured number, compound 3's estimate is 13-fold (1.11 log units) above it; the measured number lies below the stated range.
By their numbers in this assay, from the lowest: compound 3; then compounds 1 and 2 (each within the scatter of the next).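

In this assay, among the compounds shown here, the aromatic carbon ortho to a methyl group proves far less tolerant than the earlier compounds suggested: trifluoromethyl in place of hydrogen there gives a 12-fold lower number from compound 1 to compound 3 (1.07 log units; beyond the scatter) and stands beyond the scatter, whereas the only earlier step, a 1.4-fold higher number from compound 1 to compound 2 (0.13 log units; within the scatter), stayed within it. The earlier pair therefore says little about this carbon, since a small change on a saturated chain carbon gave no hint that a single substitution on the six-membered aromatic ring could shift the circulating amount this far. No measurement at hand bears on why the number falls.

From the compounds shown here alone, with one substituent at this carbon, it remains open whether the fall belongs to trifluoromethyl itself or would follow any group placed there, and a nitrile, a methoxy group or a single chlorine at the same carbon would help separate the two. Going by these compounds, it is also open whether the methyl group matters to the size of the step, a question that compound 1 and compound 3 alone cannot settle and that trifluoromethyl at this carbon with hydrogen in place of the methyl group would address.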